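This account rests on a few compounds, and the source may have more. Where it says the series, first, only, none or still open, it means among the compounds named here.

Three related compounds have been read so far. Within the data shown here, compound 1 `CC(C)=CCC/C(C)=C/CC/C(C)=C/CC[C@]1(C)CCc2cc(OC(=O)NS(=O)(=O)c3ccc(C)cc3)cc(C)c2O1` gives 6600 nM in a functional assay on MDA-MB-231 cells (Homo sapiens) for antiproliferative activity, read by MTT assay, with a stated time of 96 h (a higher number here means a weaker inhibitor, a lower number a stronger inhibitor), the only actual number in the set. Compound 2 `CC(C)=CCC/C(C)=C/CC/C(C)=C/CC[C@]1(C)CCc2c(C)c(OC(=O)NS(=O)(=O)c3ccccc3)c(C)c(C)c2O1` reads > 10000 nM, which is a limit of the assay and not a number. Compound 3 `CC(C)=CCC/C(C)=C/CC/C(C)=C/CC[C@]1(C)CCc2cc(OC(=O)Nc3ccccc3)c(C)c(C)c2O1` reads > 10000 nM, again a limit.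

Compound 4 `CC(C)=CCC/C(C)=C/CC/C(C)=C/CC[C@]1(C)CCc2cc(OC(=O)NCc3ccccc3)cc(C)c2O1` departs from compound 1 in one place: benzyl in place of (4-methylphenyl)sulfonyl on an amide-type nitrogen. Among the measured compounds shown here, no measured pair shows this change on its own, so any expectation here is indirect. A sulfonyl group does not secure a measurable reading, since compound 2 carries one and still ends at a limit. Even so, compound 3, which has no sulfonyl group on that nitrogen, sits at > 10000 nM, a limit, and this points to a loss rather than a gain for compound 4.

The expected change in this assay is a modest move toward weaker inhibition, estimated as a 2.3-fold higher number from compound 1 to compound 4 (0.36 log units; beyond the scatter), and the result may well be reported only as a limit. For compound 4 the estimated value is 15000 nM, with an expected range from 6000 nM to 40000 nM.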

Compound 4, half-maximal inhibitory concentration: > 10000 nM
Compound 4 ended at the assay's limit; the forecaster's own chance of this, stated with the estimate: 65%; the middle value lies beyond the limit too.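

In this assay compound 4 gives > 10000 nM, which is a limit of the assay and not a number. The swap of (4-methylphenyl)sulfonyl for benzyl on this amide-type nitrogen can now be read on its own, with the rest of compound 1 unchanged, and the step is an at least 1.5-fold higher number from compound 1 to compound 4 (0.18 log units; that floor lies within the scatter); this shows that benzyl does not bring a stronger reading here, but since the floor of the step lies within the scatter, it does not by itself establish a real loss. The true size of the step cannot be read from this result, and the assay's ceiling restricts what the set can show more generally: the limit of > 10000 nM in this assay, at which 3 of the 4 values shown sit.

The compounds shown leave open whether any other group on this nitrogen would give an actual number, such as a methanesulfonyl group or a (4-carboxyphenyl)sulfonyl group, which would carry a carboxylic acid. They also leave open whether a longer chain between the nitrogen and the phenyl ring, such as 2-phenylethyl, would read any differently from benzyl.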